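This account rests on a few compounds, and the source may have more. Where it says the series, first, only, none or still open, it means among the compounds named here.

Series notes. In an ADME assay on L1210/0 cells (Mus musculus) for cytotoxicity, with a stated time of 48 h (a lower number here means a stronger inhibitor, a higher number a weaker inhibitor), compound 3 `O=c1[nH]c(=O)n([C@H]2C[C@H](O)[C@@H](CO)O2)cc1[N+](=O)[O-]` gives 130 nM, the lowest of the three numbers in hand. Nearest to it stands compound 1 `Cc1ccc(C(=O)/C=C/c2cc(=O)[nH]c(=O)n2COCCO)cc1`, which gives 27900 nM, a gap beyond the scatter; furthest stands compound 2 `C#Cc1cn([C@@H]2O[C@H](CO)[C@@H](O)[C@@H]2O)c(=O)[nH]c1=O`, which gives 168000 nM, also beyond the scatter. Compound 4 `C[S+]([O-])c1cn([C@H]2C[C@H](O)[C@@H](CO)O2)c(=O)[nH]c1=O` has not been measured. It differs from compound 3 in one place: a group of 3 heavy atoms (1 carbon, 1 oxygen, 1 sulfur; no ring) in place of a group of 3 heavy atoms (1 nitrogen, 2 oxygen; no ring), on an aromatic carbon. For the measured compounds named here, no measured pair in hand carries a change of this kind, so nothing comparable can be drawn on. The expectation is a sizeable loss, with the step estimated at a 150-fold higher number from compound 3 to compound 4 (2.19 log units; beyond the scatter) towards a weaker number. Compound 4 is therefore expected near 20000 nM, within 2000 nM to 200000 nM. Confidence in this estimate is low.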

Compound 4, half-maximal inhibitory concentration: > 200000 nM
Compound 4: only a limit was reported; the forecaster's own chance of this, stated with the estimate: 15%; at least 10-fold (1.00 log units) between middle value and limit.
By their numbers in this assay, from the lowest: compound 3; then compound 1; then compound 2. At a limit, above all of these: compound 4.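

For the compounds shown here, this is the first pair that differs in one place, and it shows that this aromatic carbon alone can decide the read-out on an otherwise shared core. In this assay, replacing nitro with the group of 3 heavy atoms (1 carbon, 1 oxygen, 1 sulfur) gives an at least 1500-fold higher number from compound 3 to compound 4 (3.18 log units; beyond the scatter). The reading for compound 4 is a limit and not a number: the limit of > 200000 nM in this assay, at which 1 of the 4 values shown sits.

From the compounds shown here alone, it remains open whether nitro is unusually favourable here or the entering group is unusually poor. Going by these compounds, how an amine, a nitrile or a bromine atom on this carbon would read also remains open.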